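A few compounds are considered here, and "the series" means these few. Any claim that something is new, unique, unknown or untested is made for them only; others in the source may bear on it.

Compound 1 `Cc1cc2nnn(C(=O)c3ccccc3)c2cc1C` and compound 2 `COc1ccc(C(=O)n2nnc3ccccc32)cc1` share one core and differ in the groups arranged around it. In an assay for inhibition of Alpha amylase (Homo sapiens), with a stated time of 10 min (on this read-out lower numbers stand for stronger inhibition and higher numbers for weaker inhibition), compound 1 gives 3320 nM. In this assay compound 2 gives 2980 nM, which sits at the low end of the two figures shown, yet the gap to compound 1 lies within the scatter of repeated measurements, so on these numbers the two compounds cannot be told apart. Compound 3 `O=C(c1ccc([N+](=O)[O-])cc1)n1nnc2ccccc21` has not yet been measured. It differs from compound 2 in one place: nitro in place of methoxy on an aromatic carbon. For the measured compounds named here, no pair of measured compounds that differ in only a single place is available, so there is no measured step that shows how much such a swap shifts the read-out. With nothing to anchor it, the change is expected to move the number little, and the expected shift is a 1.2-fold lower number from compound 2 to compound 3 (0.08 log units; within the scatter), which stays within the scatter. Compound 3 is therefore expected to give about 2500 nM in this assay, most likely falling between 800 nM and 8000 nM.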

Compound 3, half-maximal inhibitory concentration: 2920 nM
Estimate against measurement, compound 3: 1.2-fold (0.07 log units) below, within the range that was stated.
By their numbers in this assay, from the lowest: compounds 3, 2 and 1 (each within the scatter of the next).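

For the compounds shown here, the swap of methoxy for nitro, on an aromatic carbon para to a large group, gives the first measured step between compounds that differ in only one place in this assay, and that step is a 1.0-fold lower number from compound 2 to compound 3 (0.01 log units; within the scatter), so on these numbers compound 2 and compound 3 cannot be told apart. The two groups differ in their atoms, in their heavy-atom count and in their count of hydrogen-bond acceptors, yet this read-out does not separate them at this position, which is something that the earlier comparison of compound 1 and compound 2, with its several differences, could not show. Nothing measured here accounts for how close the two compounds stand.

Going by these compounds alone, this single pair covers only two groups at one position, so it cannot say whether the position would tolerate any group in the same way, and an amine, a carboxylic acid or a longer chain such as butoxy at the same carbon could still stand apart from methoxy and nitro. It also leaves open whether the same swap would give a similar step on a compound carrying the two methyl groups of compound 1.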